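Methoxy to Hydroxy on a Pyridyl-Pyrazole Urea

The source may hold more compounds than are shown below. What is called first, only, known or untested is meant among the compounds shown, and "the series" means these compounds.

Of the compounds shown here, three sharing one core have been measured in a functional assay on KM12 cells (Homo sapiens) for inhibition, read by sulforhodamine B assay, with a stated time of 48 h; on this read-out lower numbers stand for stronger inhibition and higher numbers for weaker inhibition. Compound 1 `O=C(Nc1cccc(-n2cc(-c3ccncc3)c(-c3ccc(Cl)c(O)c3)n2)c1)Nc1cccc(C(F)(F)F)c1` gives 1330 nM, compound 2 `O=C(Nc1cccc(-n2cc(-c3ccncc3)c(-c3ccc(Cl)c(O)c3)n2)c1)Nc1ccc(Cl)c(Cl)c1` gives 1010 nM, and compound 3 `COc1cc(-c2nn(-c3cccc(NC(=O)Nc4ccc(Cl)c(C(F)(F)F)c4)c3)cc2-c2ccncc2)ccc1Cl` gives 1060 nM. Compound 3 holds the second highest of the three numbers; compound 2 is nearest to it and compound 1 furthest, with both gaps within the scatter, so no order among the three can be read. Among the measured compounds shown here, the only single-point step measured so far, a 1.3-fold lower number from compound 1 to compound 2 (0.12 log units; within the scatter), concerns the aryl on the urea nitrogen and not the oxygen.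

Compound 4 `O=C(Nc1cccc(-n2cc(-c3ccncc3)c(-c3ccc(Cl)c(O)c3)n2)c1)Nc1ccc(Cl)c(C(F)(F)F)c1` differs from compound 3 by hydrogen in place of methyl on an oxygen on an aromatic ring. For the measured compounds named here, no measured step touches this oxygen, so nothing in the data argues for a shift in this assay beyond the scatter. For compound 4 the expected step is therefore a 1.1-fold lower number from compound 3 to compound 4 (0.03 log units; within the scatter), that is, no change beyond the scatter. Compound 4 is estimated at 1000 nM, with a range from 400 nM to 2600 nM in this assay.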

Compound 4, half-maximal inhibitory concentration: 1000 nM
The estimate for compound 4 equals the measured number at the digits printed; the measured number falls inside the stated range.
By their numbers in this assay, from the lowest: compounds 4, 2, 3 and 1 (each within the scatter of the next).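

In this assay, among the compounds shown here, the change from methoxy to hydroxy, which turns 4-chloro-3-methoxyphenyl into 4-chloro-3-hydroxyphenyl, gives a 1.1-fold lower number from compound 3 to compound 4 (0.03 log units; within the scatter) and is the first measured step at this oxygen; in this one pair, the exchange of methyl for hydrogen does not move the number beyond the scatter. With the hydroxy kept, trifluoromethyl in place of chloro on an aromatic carbon gives a 1.0-fold lower number from compound 2 to compound 4 (0.00 log units; within the scatter) and chloro in place of hydrogen on an aromatic carbon gives a 1.3-fold lower number from compound 1 to compound 4 (0.12 log units; within the scatter) and neither step lies beyond the scatter. The data offer no explanation for any of these results.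

The compounds shown leave open whether an amine or a carboxylic acid on this aromatic carbon, or a longer chain such as ethoxy on the oxygen, would shift the number beyond the scatter. They also leave open whether the methoxy to hydroxy change would stay this small with another aryl on the urea.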